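A Single Stereocentre Redrawn from Compound 2

This account rests on a few compounds, and the source may have more. Where it says the series, first, only, none or still open, it means among the compounds named here.

Of the compounds shown here, two have numbers so far in an ADME assay on HepG2 cells (Homo sapiens) for cytotoxicity (a lower number here means that less compound is tolerated, a higher number that more compound is tolerated), and they sit apart. Compound 1 `CC(=O)c1cccc(N2C(=O)CN(c3cccc(C(F)(F)F)c3)CC2C(=O)NC2CCCC2)c1` gives 40000 nM there, whereas compound 2 `O=C(NC1CCCC1)[C@H]1CN(c2ccc(C(F)(F)F)cc2)CC(=O)N1c1ccc2ccsc2c1` gives 10000 nM and so stands lowest of the pair, with a gap beyond the usual scatter of repeats. For the measured compounds named here, no two measured compounds differ in one place only, so no measured step guides what follows.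

Compound 3 `O=C(NC1CCCC1)[C@@H]1CN(c2ccc(C(F)(F)F)cc2)CC(=O)N1c1ccc2ccsc2c1` has not yet been measured. It departs from compound 2 only in configuration as drawn the two compounds have the same atoms and bonds and differ only in configuration as drawn: 1 of 1 stereo elements differ; a stereocentre at a saturated ring carbon is drawn R in compound 2 and S in compound 3 and the two have the same atoms and bonds, with a stereocentre at a saturated ring carbon drawn R in compound 2 and S in compound 3. With nothing measured on such a change, no step beyond the scatter is expected in this assay. The reading for compound 2 at 10000 nM remains the best anchor. The estimated move is a 1.2-fold higher number from compound 2 to compound 3 (0.08 log units; within the scatter) and it is expected to stay within the scatter. For compound 3 the estimate is 12000 nM with an expected range from 5000 nM to 40000 nM for this measurement.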

Compound 3, half-maximal cytotoxic concentration: 20000 nM
Compound 3: the middle estimate sits 1.7-fold (0.22 log units) below what was measured; measured number inside the range.
By their numbers in this assay, from the lowest: compounds 2, 3 and 1 (each within the scatter of the next, the first and the last beyond it).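

Redrawing the stereocentre at a saturated ring carbon from R to S gives a 2.0-fold higher number from compound 2 to compound 3 (0.30 log units; within the scatter) in this assay, the first step in this set that can be read for a single change. That step lies within the scatter, so the numbers give no sign that the configuration at this carbon separates the two compounds in this assay. The step can be read for the stereocentre alone, with no other change in the structures to share it: the fact that compounds 2 and 3 differ only in the configuration as drawn

As far as these compounds go, whether the configuration at this carbon would stay just as silent in a compound that carries an amine or a carboxylic acid remains open, since this one pair speaks only for the groups it holds. Compound 1 differs from the other two compounds in more than one place, so the compounds shown do not tie its number to any single change, and they do not say whether the same redrawing would give a step of similar size on the core of compound 1.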